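A larger ring group on the most active compound

The compounds below may be only part of what the source reports. "The series", "measured", "known", "first", "only" and "open" are said of these compounds alone.

- compound 1 `CC1=C(c2ccc(S(C)(=O)=O)cc2)C(c2ccc(OC[C@H](C)N3CC[C@@H](C)C3)cc2)Oc2ccc(O)cc21` gives 27 nM
- compound 2 `CC1=C(c2cccc(O)c2)C(c2ccc(OC[C@H](C)N3CCCC3)cc2)Oc2ccc(O)cc21` gives 0.2 nM
- compound 3 `CC1=C(c2ccc(C#N)cc2)C(c2ccc(OC[C@H](C)N3CC[C@@H](C)C3)cc2)Oc2ccc(O)cc21` gives 10 nM

In a functional assay on MCF7 cells (Homo sapiens) for antiproliferative activity, read by CellTiter-Glo, with a stated time of 5 days (a higher number here means a weaker inhibitor, a lower number a stronger inhibitor), compound 2 has the lowest number of the three, and its gaps to compound 1 and compound 3 lie beyond the scatter. Compound 4 `CC1=C(c2cccc(O)c2)C(c2ccc(OC[C@@H](C)N3CC[C@H](C)C3)cc2)Oc2ccc(O)cc21` differs from compound 2 by a group of 8 heavy atoms (7 carbon, 1 nitrogen; one five-membered non-aromatic ring with 1 hetero atom) in place of a group of 7 heavy atoms (6 carbon, 1 nitrogen; one five-membered non-aromatic ring with 1 hetero atom), on a saturated chain carbon bound to an oxygen on an aromatic ring. Among the compounds with values here, no measured step changes that group. Within the data shown here, the only step available, a 2.7-fold lower number from compound 1 to compound 3 (0.43 log units; beyond the scatter), sits on an aromatic carbon elsewhere in the molecule, so it offers a rough sense of size and no direct guide. Compound 1 and compound 3 also differ from compound 2 in more than one place, so their higher values cannot be traced to this group alone. A modest change is therefore the working expectation, and since compound 2 already stands lowest at 0.2 nM, the likelier direction is upward. The expected shift is a 4.0-fold higher number from compound 2 to compound 4 (0.60 log units; beyond the scatter). For compound 4 the estimated value is 0.8 nM, with an expected range from 0.15 nM to 5 nM.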

Compound 4, half-maximal inhibitory concentration: 0.2 nM
The estimate for compound 4 lay 4.0-fold (0.60 log units) above the measured number, within the range that was stated.
By their numbers in this assay, from the lowest: compounds 2 and 4 (each within the scatter of the next); then compound 3; then compound 1.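

In this assay, within the data shown here, the change on the saturated chain carbon bound to an oxygen on an aromatic ring gives no change at the digits printed from compound 2 to compound 4 (within the scatter) and is the first direct reading at this position. A group of 8 heavy atoms with 2 defined stereocentres replaces a group of 7 heavy atoms with 1 defined stereocentre, and the number stays within the scatter, so this extra carbon brings no measurable loss in these cells. No measurement shown here accounts for this result.

The added carbon and the extra stereocentre arrive together, so this single step cannot separate what each contributes. As far as these compounds go, it is also open whether a piperidine or a dimethylamino group at the same place would hold the number as well.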